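Lengthening the amide chain by one more carbon

A few compounds are considered here, and "the series" means these few. Any claim that something is new, unique, unknown or untested is made for them only; others in the source may bear on it.

Among the measured compounds shown here, the three compounds measured so far share one core and differ only in the group attached to the amide nitrogen. In a functional assay on the whole organism (strain Swiss albino) for inhibition, with Mus musculus as the target, in the writhing test, with stated times of 60 min and 15 min, at a dose of 100 mg/kg by the oral route (on this read-out lower numbers stand for less inhibition and higher numbers for more inhibition at the one dose given (going by the name of the read-out)), compound 1 `CCNC(=O)CC1CCc2cc(OC)c(OC)cc21` gives 23.6%, compound 2 `COc1cc2c(cc1OC)C(CC(=O)NC(C)C)CC2` gives 29.3%, and compound 3 `CCCCCNC(=O)CC1CCc2cc(OC)c(OC)cc21` gives 71.7%. Compound 3 stands highest of the three, and its steps to the other two are beyond the scatter: a number 48.1 percentage points higher from compound 1 to compound 3 (beyond the scatter) and a number 42.4 percentage points higher from compound 2 to compound 3 (beyond the scatter). The step of a number 5.7 percentage points higher from compound 1 to compound 2 (within the scatter) lies within the scatter. Compound 4 `CCCCCCNC(=O)CC1CCc2cc(OC)c(OC)cc21` carries the next longer chain on the amide nitrogen: methyl in place of hydrogen on a saturated chain carbon, five bonds along the chain from an amide-type nitrogen. The two steps that bear on this change both replaced a short group on the amide nitrogen with a pentyl chain, and both were large rises in this assay. For the measured compounds named here, compound 4 continues in that direction by a single carbon, a much smaller structural change than either of those steps, and no measured compound tells whether the rise continues, levels off or reverses past pentyl. Compound 4 is therefore expected to give 74%, between 55% and 90%, a step of a number 2.3 percentage points higher from compound 3 to compound 4 (within the scatter) that is expected to lie within the scatter.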

Compound 4, a percentage reported as inhibition, in the whole organism at one dose (the size of the read-out at that dose, not a potency): 82.2%
Compound 4: the middle estimate sits 8.2 percentage points below what was measured; the range from low to high includes it.
By their numbers in this assay, from the lowest: compounds 1 and 2 (each within the scatter of the next); then compound 3; then compound 4.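

In this assay the rise does not stop at pentyl: a methyl in place of hydrogen, five bonds along the chain from the amide-type nitrogen, gives a number 10.5 percentage points higher from compound 3 to compound 4 (beyond the scatter), a modest step but a real one. Compound 4, with its hexyl chain, now stands highest of the four, and the gap to the compounds with short groups on the amide nitrogen has widened, with a number 52.9 percentage points higher from compound 2 to compound 4 (beyond the scatter) and a number 58.6 percentage points higher from compound 1 to compound 4 (beyond the scatter). Set side by side, the step from adding a methyl does not clearly differ in size between the short group and the long chain: the same change on two cores in this assay, a number 5.7 percentage points higher (within the scatter) from compound 1 to compound 2 and a number 10.5 percentage points higher (beyond the scatter) from compound 3 to compound 4, 4.8 percentage points apart, within the scatter of two such steps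

A heptyl or octyl chain on the amide nitrogen would show whether the rise goes on, levels off or reverses beyond hexyl. Also open is how this position would respond to a chain ending in an amine or a carboxylic acid, or to a cyclohexyl or phenyl ring in place of the chain, and readings at a single dose cannot show how potent any of these compounds is.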